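Two measured analogues and a chloro substitution

A few compounds are considered here, and "the series" means these few. Any claim that something is new, unique, unknown or untested is made for them only; others in the source may bear on it.

Measured so far:
compound 1 `COc1ccc(N2C(=O)C(C)(C)c3cccnc32)cc1` — 0%
compound 2 `CC1(C)C(=O)N(c2ccccc2)c2ncccc21` — 24%

In a functional assay on the whole organism with Rattus norvegicus as the target, at a dose of 25 mg/kg (on this read-out higher numbers stand for more inhibition at the one dose given (going by the name of the read-out) and lower numbers for less inhibition), compound 1 gives 0%, while compound 2 gives 24%. Compound 2 stands highest of the two numbers; its nearest neighbour is compound 1, and the step of a number 24 percentage points higher from compound 1 to compound 2 (beyond the scatter) is beyond the usual scatter. Compound 3 `CC1(C)C(=O)N(c2cccc(Cl)c2)c2ncccc21` is not yet measured. The change from compound 2 is chloro in place of hydrogen on an aromatic carbon. Among the compounds with values here, only one measured step exists, a number 24 percentage points higher from compound 1 to compound 2 (beyond the scatter), and it concerns a different group in a different place; it bears on compound 3 only in showing that a single substituent on that ring can shift this assay by a modest amount. The direction of the new change is therefore not known, and the expectation rests mostly on compound 2. Compound 3 is estimated at 30%, range 8% to 55%. The expected step is a number 6 percentage points higher from compound 2 to compound 3 (within the scatter), within the scatter.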

Compound 3, a percentage reported as inhibition, in the whole organism at one dose (the size of the read-out at that dose, not a potency): 31%
Compound 3: middle estimate off by 1 percentage points, on the low side; the measured number falls inside the stated range.
By their numbers in this assay, from the lowest: compound 1; then compounds 2 and 3 (each within the scatter of the next).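

In this assay, chloro in place of hydrogen on an aromatic carbon, meta to a large group, gives a number 7 percentage points higher from compound 2 to compound 3 (within the scatter) and so leaves compound 2 and compound 3 not separated. Within the data shown here, this position therefore accepts a chlorine without a change that can be read, whereas the only earlier step, a number 24 percentage points higher from compound 1 to compound 2 (beyond the scatter), involved methoxy and lay beyond the scatter. Nothing further is available to explain this result.

Only hydrogen and chloro are shown at this position, so it remains open whether an amine, a carboxylic acid or a longer chain placed there would move the number beyond the scatter. Also open, as far as these compounds go, is how chloro would read elsewhere on the same ring, and whether the single dose hides any difference between compound 2 and compound 3.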